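This account rests on a few compounds, and the source may have more. Where it says the series, first, only, none or still open, it means among the compounds named here.

The measured compounds in this set are:

Compound 1, `CC(C)[Si]1(C(C)C)OC[C@H]2O[C@@H](n3ccc(=O)[nH]c3=O)[C@H](O)[C@@H]2O[Si](C(C)C)(C(C)C)O1`, measured at 81000 nM
Compound 2, `CC(=O)O[C@@H]1[C@H](OC(C)=O)[C@@H](CO[Si](c2ccccc2)(c2ccccc2)C(C)(C)C)O[C@H]1n1ccc(=O)[nH]c1=O`, measured at 32000 nM
Compound 3, `CC(=O)O[C@@H]1[C@H](OC(C)=O)[C@@H](CO[Si](c2ccccc2)(c2ccccc2)C(C)(C)C)O[C@H]1n1ccc(=O)n(C(=O)c2ccccc2)c1=O`, measured at 26000 nM

All three were tested in a functional assay on U-373MG ATCC cells (Homo sapiens) for inhibition, read by MTT assay, with a stated time of 72 h; on this read-out lower numbers stand for stronger inhibition of growth and higher numbers for weaker inhibition of growth. Compound 1 gives the highest number of the three, 81000 nM. Compound 2, whose core is built differently, gives 32000 nM. The difference between the core of compound 1 and the core of compound 2 is not broken down here; it can only be said that compound 2 gives a lower number than compound 1.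

Compound 3 is compound 2 carrying (benzoyl in place of hydrogen on an aromatic nitrogen). This change made a step of a 1.2-fold lower number from compound 2 to compound 3 (0.09 log units; within the scatter), so the benzoyl left the read-out in this assay essentially unchanged.

Compound 4, `CC(C)[Si]1(C(C)C)OC[C@H]2O[C@@H](n3ccc(=O)n(C(=O)c4ccccc4)c3=O)[C@H](O)[C@@H]2O[Si](C(C)C)(C(C)C)O1`, has not yet been measured. It stands to compound 1 as compound 3 stands to compound 2: it carries benzoyl in place of hydrogen on an aromatic nitrogen, and the surroundings of the change are the same word for word in both pairs, so this is the same change on a different core. The expectation for compound 4 therefore rests on the step from compound 2 to compound 3: compound 4 is expected to differ from compound 1 by a 1.2-fold lower number from compound 1 to compound 4 (0.06 log units; within the scatter), a step within the usual scatter, because the earlier step of a 1.2-fold lower number from compound 2 to compound 3 (0.09 log units; within the scatter) was itself within the scatter. On that basis compound 4 is estimated to give about 70000 nM in this assay, expected to fall between 30000 nM and 160000 nM. A single pair is a thin basis, and a different outcome on the core of compound 1 cannot be ruled out.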

Compound 4, concentration for 50% growth inhibition: 29000 nM
Compound 4: middle estimate off by 2.4-fold (0.38 log units), on the high side; measured number outside the range, below it.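

In this assay the benzoyl in place of hydrogen on the aromatic nitrogen gave a 2.8-fold lower number from compound 1 to compound 4 (0.45 log units; beyond the scatter) and this modest step is larger than the one seen earlier on the other core. Set side by side, however, the two steps cannot be told apart, since the gap between them does not exceed what repeated measurements of two such steps would produce: the same change on two cores in this assay, a 1.2-fold lower number (0.09 log units; within the scatter) from compound 2 to compound 3 and a 2.8-fold lower number (0.45 log units; beyond the scatter) from compound 1 to compound 4, 2.3-fold (0.36 log units) apart, within the scatter of two such steps. The result is therefore compatible with the change carrying over from one core to the other with a similar, small lowering of the number, but two pairs do not establish a fixed size for it, and they show neither that the core of compound 1 responds more strongly nor that the step would hold on any further core.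

The compounds shown leave open whether anything other than benzoyl on the aromatic nitrogen, such as an acetyl group, a longer alkyl chain, or a benzoyl ring carrying an amine or a carboxylic acid, would move the number further or not at all. They also leave open whether the same step would appear in other cell lines, as all of these readings come from a single assay.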